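This account rests on a few compounds, and the source may have more. Where it says the series, first, only, none or still open, it means among the compounds named here.

Of the compounds shown here, two have been measured so far. In a functional assay on U-87MG ATCC cells for antiproliferative activity against U-87 MG (Homo sapiens), read by MTT assay, with a stated time of 48 h, tested at 100 uM (a higher number here means a weaker effect of the compound at the concentration tested, a lower number a stronger effect), compound 1 `COc1ccc(-c2nc(C)c(C(=O)CSc3nc(-c4ccc(Cl)cc4)c(C#N)c(=O)[nH]3)s2)cc1` gives 2.85%, and compound 2 `COc1ccc(-c2nc(SCC(=O)c3sc(-c4ccc(Cl)cc4)nc3C)[nH]c(=O)c2C#N)cc1` gives 16.6%. Compound 2 thus stands highest of the two numbers, with compound 1 lower by a gap beyond the usual scatter. Compound 3 `Cc1nc(-c2ccc(Cl)cc2)sc1C(=O)CSc1nc(-c2ccc(Cl)cc2)c(C#N)c(=O)[nH]1` has not yet been measured. It differs from compound 2 in one place: chloro in place of methoxy on an aromatic carbon. Among the measured compounds shown here, no measured pair carries this change, so its size cannot be read from the numbers. A step of a number 3.6 percentage points lower from compound 2 to compound 3 (within the scatter) in this assay is expected, within the scatter. Compound 3 is expected to give about 13%, between 2% and 30%.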

Compound 3, a percentage reported as activity, at one concentration (the size of the read-out at that concentration, not a potency): 12.8%
For compound 3 the middle estimate is 0.2 percentage points above the measured one; measured number inside the range.
By their numbers in this assay, from the lowest: compounds 1, 3 and 2 (each within the scatter of the next, the first and the last beyond it).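

In this assay the change from 4-methoxyphenyl to 4-chlorophenyl can now be read at two places on the shared core, as a number 3.8 percentage points lower from compound 2 to compound 3 (within the scatter) and as a number 10 percentage points higher from compound 1 to compound 3 (within the scatter) on the other aryl ring. Neither step lies beyond the scatter, so at both places chloro and methoxy are not told apart in this read-out at the single concentration tested. The compounds shown leave open how an amine or a carboxylic acid would read at the same position. Nothing measured here explains these results.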